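A Doubly Substituted Ring Replaces the Chlorophenyl Arm

This account rests on a few compounds, and the source may have more. Where it says the series, first, only, none or still open, it means among the compounds named here.

Compound 1 `C=CCn1c(=O)/c(=C\c2cccc(Cl)c2)[nH]c(=O)/c1=C\c1ccccc1OC` was tested in a functional assay on MOLT-4 cells (Homo sapiens) for cytotoxicity, read by CCK-8 assay, with a stated time of 72 h (a lower number here means a stronger inhibitor, a higher number a weaker inhibitor), and gave 4900 nM. Among the compounds with a reported number it holds the lowest value, but its nearest neighbour, compound 2 `C=CCn1c(=O)/c(=C\c2cccc(F)c2)[nH]c(=O)/c1=C\c1ccccc1OC`, gives 6500 nM in this assay, and the step of a 1.3-fold higher number from compound 1 to compound 2 (0.12 log units; within the scatter) is within the scatter, so the two cannot be ordered. Compound 3 `C=CCn1c(=O)/c(=C\c2ccc(F)c(Br)c2)[nH]c(=O)/c1=C\c1ccccc1OC` was reported in this assay as "not active" (no number reported), without a number.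

Compound 4 `C=CCn1c(=O)/c(=C\c2cc(F)ccc2C)[nH]c(=O)/c1=C\c1ccccc1OC` differs from compound 1 in one place: 5-fluoro-2-methylphenyl in place of 3-chlorophenyl on a double-bonded chain carbon bound to an aromatic carbon. For the measured compounds named here, no measured step matches this change. Going by the values given here, the only single-place step, from compound 1 to compound 2, is an exchange of one halogen and is within the scatter. Compound 3, which carries two substituents on the same ring, gave no number, which is the only hint about a more substituted ring and points toward a weaker result. Compound 4 is therefore expected to show a step of a 1.6-fold higher number from compound 1 to compound 4 (0.21 log units; within the scatter), a modest rise in the number. The estimate for compound 4 in this assay is 8000 nM, with a range from 3000 nM to 25000 nM.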

Compound 4, half-maximal inhibitory concentration: 3800 nM
Estimate against measurement, compound 4: 2.1-fold (0.32 log units) above, and the stated range covers the measured number.
By their numbers in this assay, from the lowest: compounds 4, 1 and 2 (each within the scatter of the next).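

In this assay, 5-fluoro-2-methylphenyl in place of 3-chlorophenyl gives a 1.3-fold lower number from compound 1 to compound 4 (0.11 log units; within the scatter), and methyl in place of hydrogen on an aromatic carbon gives a 1.7-fold lower number from compound 2 to compound 4 (0.23 log units; within the scatter); neither step can be told from the scatter. This place on the double-bonded chain carbon therefore keeps a measurable number with two substituents on the ring. Compound 3, also carrying two substituents on its ring, was reported as not active while compound 4 has a number, so the presence of two substituents alone does not decide the outcome, and no data are available that explain the difference.

The compounds shown leave open whether this ring keeps a number when it carries an amine or a carboxylic acid rather than halogen or methyl. They also leave open which substituent arrangement separates compound 3 from compound 4.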